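The compounds below may be only part of what the source reports. "The series", "measured", "known", "first", "only" and "open" are said of these compounds alone.

Measured in a functional assay on HepG2 cells (Homo sapiens) for cytotoxicity, read by MTT assay, with a stated time of 24 h; a higher number here means a weaker inhibitor, a lower number a stronger inhibitor:
- compound 1 `COc1cc(/C=C2\CN(C)C/C(=C\c3ccccc3F)C2=O)cc(OC)c1OC`: 670 nM
- compound 2 `COc1cc(/C=C2\CN(C)C/C(=C\c3cc(OC)c(OC)c(OC)c3)C2=O)cc(OC)c1`: 890 nM
- compound 3 `COc1cc(/C=C2\CN(C)C/C(=C\c3ccc(F)cc3)C2=O)cc(OC)c1OC`: 7340 nM

Compound 3 has the highest number of the three, and its steps to both others lie beyond the scatter, so it is the weakest inhibitor of this small set. The next compound, compound 4 `COc1cc(/C=C2\CN(C)C/C(=C\c3ccc(Cl)cc3)C2=O)cc(OC)c1OC`, differs from it by chloro in place of fluoro on an aromatic carbon, para to a large group.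

Within the data shown here, no measured step makes this exchange. The nearest evidence is two changes of the aryl group at the same place, the large 11-fold higher number from compound 1 to compound 3 (1.04 log units; beyond the scatter) and the modest 8.2-fold higher number from compound 2 to compound 3 (0.92 log units; beyond the scatter). Together they show that this aryl group can move the number well beyond the scatter, but they give no direction for a swap of one halogen for another. Among the measured compounds shown here, with only three compounds, a modest move toward the other two is expected, with wide uncertainty. The expected step is a 2.1-fold lower number from compound 3 to compound 4 (0.32 log units; beyond the scatter). Compound 4 is estimated at 3500 nM, with an expected range of 1000 nM to 10000 nM.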

Compound 4, half-maximal inhibitory concentration: 8250 nM
The estimate for compound 4 lay 2.4-fold (0.37 log units) below the measured number; low and high end bracket the measured number.
By their numbers in this assay, from the lowest: compounds 1 and 2 (each within the scatter of the next); then compounds 3 and 4 (each within the scatter of the next).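

In this assay, among these compounds, this is the first step that exchanges one halogen for another at a single place, and at a 1.1-fold higher number from compound 3 to compound 4 (0.05 log units; within the scatter) it stays within the scatter, so the numbers do not tell 4-fluorophenyl and 4-chlorophenyl apart. The gap to the other aryl groups holds for the chloro compound as well: a 9.3-fold higher number from compound 2 to compound 4 (0.97 log units; beyond the scatter) and a 12-fold higher number from compound 1 to compound 4 (1.09 log units; beyond the scatter) both lie beyond the scatter, as the matching steps to compound 3 do. No measurement at hand accounts for any of these steps.

Two halogens at one place do not show whether a group of another kind, such as an amine or a carboxylic acid, would stay with compounds 3 and 4 or move toward compounds 1 and 2. Also open, going by these compounds, is whether a chloro in the place the fluoro holds in compound 1 would give a number like that of compound 1.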